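Hydrazone aryl variation on the shared core: compound 4

The source may report more compounds than this note shows. Statements on the series, on what has been measured and on what is new or still open speak of the compounds shown alone.

Measured so far:
compound 1 `Cn1c(=O)c(=O)n(C2CCCC2)c2nc(N/N=C/c3ccccc3)ncc21` in a functional assay on A549 cells (Homo sapiens) for antiproliferative activity, read by MTT assay; on this read-out lower numbers stand for stronger inhibition and higher numbers for weaker inhibition: > 100000 nM; this is a limit of the assay, not a number
compound 2 `Cc1cccc(/C=N/Nc2ncc3c(n2)n(C2CCCC2)c(=O)c(=O)n3C)c1` in this assay: 34500 nM
compound 3 `Cn1c(=O)c(=O)n(C2CCCC2)c2nc(N/N=C/c3ccc(S(C)(=O)=O)cc3)ncc21` in this assay: 84500 nM

Compound 3 gives the highest of the two numbers in this assay; compound 2 is nearest, with a 2.4-fold higher number from compound 2 to compound 3 (0.39 log units; beyond the scatter). Compound 1 sits at a limit of the assay (the limit of > 100000 nM in this assay, at which 1 of the 3 values shown sits), so against it compound 3 shows only an at least 1.1-fold lower number from compound 1 to compound 3 (0.07 log units; that floor lies within the scatter), whereas compound 2 shows an at least 2.8-fold lower number from compound 1 to compound 2 (0.46 log units; beyond the scatter).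

Compound 4 `Cn1c(=O)c(=O)n(C2CCCC2)c2nc(N/N=C/c3cccc([N+](=O)[O-])c3)ncc21` differs from compound 3 by 3-nitrophenyl in place of 4-(methylsulfonyl)phenyl on a carbon with a double bond to nitrogen. Going by the values given here, the steps that bear on this are the aryl swap a 2.4-fold higher number from compound 2 to compound 3 (0.39 log units; beyond the scatter) and the methyl entry an at least 2.8-fold lower number from compound 1 to compound 2 (0.46 log units; beyond the scatter); both show that the aryl group of the hydrazone moves the number, and the 3-methylphenyl analogue compound 2 carries the lowest number seen. Among the compounds with values here, no measured compound carries a nitro group, so the direction for compound 4 is uncertain; a modest move is expected rather than none.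

Compound 4 is expected to give 50000 nM in this assay, with a range of 20000 nM to 130000 nM. That estimate means a 1.7-fold lower number from compound 3 to compound 4 (0.23 log units; within the scatter). Such an expected number would place compound 4 between compound 2 and compound 3.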

Compound 4, half-maximal inhibitory concentration: 12300 nM
Compound 4: middle estimate off by 4.1-fold (0.61 log units), on the high side; measured number below the stated range.
By their numbers in this assay, from the lowest: compound 4; then compound 2; then compound 3. At a limit, above all of these: compound 1.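

Going by these compounds alone, at the aryl end of the hydrazone, the number in this assay responds to the group on the ring more strongly than the earlier compounds showed, and 3-nitrophenyl in place of 4-(methylsulfonyl)phenyl gives a 6.9-fold lower number from compound 3 to compound 4 (0.84 log units; beyond the scatter). Nitro in place of methyl gives a 2.8-fold lower number from compound 2 to compound 4 (0.45 log units; beyond the scatter), so compound 4 now holds the lowest number of the measured values, and a nitro group gives a clear gain over the methyl of compound 2. Compound 1 is a limit and not a number, so the step of an at least 8.1-fold lower number from compound 1 to compound 4 (0.91 log units; beyond the scatter) is only a floor: the limit of > 100000 nM in this assay, at which 1 of the 4 values shown sits.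

Open, as far as these compounds go, is whether the gain follows the nitro group itself or its place on the ring, as methylsulfonyl and nitro are compared here only as 4-(methylsulfonyl)phenyl against 3-nitrophenyl. Also open, from the compounds shown here alone, is how an amine or a carboxylic acid on that aryl ring would compare with nitro.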